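Swapping the Group on the Carbonyl Carbon: Compound 3 to Compound 4

A few compounds are considered here, and "the series" means these few. Any claim that something is new, unique, unknown or untested is made for them only; others in the source may bear on it.

Three compounds have so far been measured in a functional assay on isolated protein for inhibition of Glucose-dependent insulinotropic receptor (Rattus norvegicus), read by HTRF and cAMP accumulation; on this read-out higher numbers stand for an effect only at larger amounts of compound and lower numbers for an effect already at smaller amounts:

Compound 1 `Cc1nc(S(C)(=O)=O)ccc1Oc1ncnc(OC2CCN(C(=O)OC(C)(C)C(F)(F)F)CC2)c1F` gives 47.2 nM.
Compound 2 `Cc1nc(S(C)(=O)=O)ccc1Oc1ncnc(OC2CCN(C(=O)OC(C)(C)CF)CC2)c1F` gives 138 nM.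
Compound 3 `Cc1nc(S(C)(=O)=O)ccc1Oc1ncnc(OC2CCN(C(=O)SC(C)(C)C)CC2)c1F` gives 30.7 nM.

Compound 3 has the lowest number of the three. Its nearest neighbour is compound 1, and the step of a 1.5-fold lower number from compound 1 to compound 3 (0.19 log units; within the scatter) lies within the scatter, so the two cannot be ordered. Compound 2 is furthest away, and the step of a 4.5-fold lower number from compound 2 to compound 3 (0.65 log units; beyond the scatter) is beyond the scatter. Within the pair of carbamates, the step of a 2.9-fold higher number from compound 1 to compound 2 (0.47 log units; beyond the scatter) shows that changing the fluorine count on the chain moves the number by a modest amount.

Compound 4 `Cc1nc(S(C)(=O)=O)ccc1Oc1ncnc(OC2CCN(C(=O)C(C)(F)F)CC2)c1F` is the next compound to be measured. It differs from compound 3 by 1,1-difluoroethyl in place of (tert-butyl)sulfanyl on a carbonyl carbon. Within the data shown here, no measured step covers exactly this change: the steps recorded so far alter groups on the carbonyl carbon but always keep a heteroatom link there, whereas compound 4 attaches a carbon-linked group directly. The two steps that bear on it, a 4.5-fold lower number from compound 2 to compound 3 (0.65 log units; beyond the scatter) and a 1.5-fold lower number from compound 1 to compound 3 (0.19 log units; within the scatter), are modest at most. The estimate therefore is a modest rise, a 2.6-fold higher number from compound 3 to compound 4 (0.42 log units; beyond the scatter), with wide uncertainty. For compound 4 the expected value in this assay is 80 nM, within a range from 25 nM to 250 nM.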

Compound 4, half-maximal effective concentration: 239 nM
Beside the measured number, compound 4's estimate is 3.0-fold (0.48 log units) below it, within the range that was stated.
By their numbers in this assay, from the lowest: compounds 3 and 1 (each within the scatter of the next); then compounds 2 and 4 (each within the scatter of the next).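

At the carbonyl carbon whose other neighbour is the amide-type nitrogen in a ring, this assay gives a 7.8-fold higher number from compound 3 to compound 4 (0.89 log units; beyond the scatter) when 1,1-difluoroethyl takes the place of (tert-butyl)sulfanyl, and this is the first change shown in which the heteroatom link to the carbonyl is lost and a carbon-linked group stands there instead. The carbon-linked group is also separated from the trifluoromethyl-bearing carbamate by a 5.1-fold higher number from compound 1 to compound 4 (0.70 log units; beyond the scatter) and that step lies beyond the scatter, whereas a 1.7-fold higher number from compound 2 to compound 4 (0.24 log units; within the scatter) lies within the scatter, so a carbon link at this position cannot be ordered against the fluoromethyl-bearing carbamate and does not stand apart from every heteroatom-linked group. Nothing available here bears on why the number moves at this position.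

Compound 4 differs from compound 3 in both the linking atom and the attached chain, so the compounds shown do not separate these two changes. From the compounds shown here alone, a tert-butyl bound straight to the carbonyl carbon, or a tert-butylamino group in the same place, would keep the chain of compound 3 while changing only the link, and how either reads in this assay remains open.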